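The compounds below may be only part of what the source reports. "The series", "measured", "known", "first", "only" and "open" are said of these compounds alone.

Measured compounds:
compound 1 `CSc1cccc(Nc2nc(-c3cccc(Cl)c3)cs2)c1`, 5300 nM
compound 2 `CSc1cccc(Nc2nc(-c3ccc(Cl)c(Cl)c3)cs2)c1`, 14000 nM

In an assay on CFBE41o cells with Cystic fibrosis transmembrane conductance regulator variant F508del (Homo sapiens) as the target, with a stated time of 24 h (on this read-out lower numbers stand for an effect already at smaller amounts and higher numbers for an effect only at larger amounts of compound), compound 1 gives the lowest of the two numbers; its nearest neighbour is compound 2, reached by a 2.6-fold higher number from compound 1 to compound 2 (0.42 log units; beyond the scatter).

Compound 3 `CSc1cccc(Nc2nc(-c3cc(Cl)cs3)cs2)c1` differs from compound 1 by 4-chlorothiophen-2-yl in place of 3-chlorophenyl on an aromatic carbon. Going by the values given here, no measured step covers a ring swap of this kind; the only step in hand, from compound 1 to compound 2, concerns an added chloro and gives no direct guidance. The expectation for compound 3 is therefore a number close to that of compound 1, with a 1.3-fold higher number from compound 1 to compound 3 (0.12 log units; within the scatter) expected to stay within the scatter and the risk leaning toward a higher number.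

Compound 3 is estimated at 7000 nM, range 2500 nM to 20000 nM.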

Compound 3, half-maximal effective concentration: "not active" (no number reported)
Nothing numeric was reported for compound 3; there is nothing to compare the estimate with.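

Going by these compounds alone, compound 3 is reported as "not active" without a number, so no step from compound 1 to compound 3 can be read. The compounds shown leave open whether any other ring in place of 3-chlorophenyl keeps a measurable number. No measured evidence bears on this result.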